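The source may report more compounds than this note shows. Statements on the series, on what has been measured and on what is new or still open speak of the compounds shown alone.

In a functional assay on A549 cells (Homo sapiens) for antiproliferative activity, read by MTT assay, with a stated time of 48 h (a lower number here means a stronger inhibitor, a higher number a weaker inhibitor), compound 1 `COc1cccc(-c2nc3cccc(-c4cc(OC)c(OC)c(OC)c4)c3o2)c1` gives 3500 nM and compound 2 `COc1cc(-c2cccc3nc(-c4cccc(F)c4)oc23)cc(OC)c1OC` gives 2600 nM, so compound 2 stands level with compound 1 within the usual scatter. Compound 3 `COc1cc(-c2cccc3nc(-c4cccc(Cl)c4)oc23)cc(OC)c1OC` carries chloro in place of fluoro on an aromatic carbon. For the measured compounds named here, only one measured step bears on this place, fluoro in place of methoxy, and it is a 1.3-fold lower number from compound 1 to compound 2 (0.13 log units; within the scatter). Going by that single step, no change beyond the scatter is expected in this assay. The expected step is a 1.0-fold lower number from compound 2 to compound 3 (0.02 log units; within the scatter). Compound 3 is estimated at 2500 nM, with a range of 1000 nM to 6000 nM.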

Compound 3, half-maximal inhibitory concentration: > 25000 nM
Compound 3 was reported as a limit (the forecaster's own chance of this, stated with the estimate: 3%); middle value at least 10-fold (1.00 log units) away from the limit.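

Compound 3 is reported only as a limit: the limit of > 25000 nM in this assay, at which 1 of the 3 values shown sits. Compound 1 and compound 2 stood level within the scatter, which made this aromatic carbon look tolerant of change, but in this assay chloro in place of fluoro gives an at least 9.6-fold higher number from compound 2 to compound 3 (0.98 log units; beyond the scatter), and chloro in place of methoxy gives an at least 7.1-fold higher number from compound 1 to compound 3 (0.85 log units; beyond the scatter). The group at this place can therefore matter a great deal, and similar results for two groups do not predict a third.

Whether the loss is peculiar to chloro stays open, as no bromo, methyl or amine at this place is shown. The compounds shown also give no reason for the loss.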